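Aryl ketone versus methyl ketone on the enone chain

A few compounds are considered here, and "the series" means these few. Any claim that something is new, unique, unknown or untested is made for them only; others in the source may bear on it.

Measured so far:
- compound 1 `COc1ccc(C(=O)/C=C/c2cc(-c3cc(OC)c(OC)c(OC)c3)n[nH]2)cc1OC`: 620 nM
- compound 2 `COc1cc(-c2cc(/C=C/C(C)=O)[nH]n2)cc(OC)c1OC`: 27300 nM

Among the compounds with values here, in a functional assay on MDA-MB-231 cells (Homo sapiens) for inhibition, read by MTT assay, with a stated time of 48 h (on this read-out higher numbers stand for weaker inhibition and lower numbers for stronger inhibition), compound 2 gives the weakest result of the two measured compounds, and the only measured neighbour of compound 2 is compound 1 with a 44-fold higher number from compound 1 to compound 2 (1.64 log units; beyond the scatter). That step exchanged an aryl group on the carbonyl carbon for a methyl and cost a large amount of inhibition.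

Compound 3 `COc1ccc(C(=O)/C=C/c2cc(-c3cc(OC)c(OC)c(OC)c3)n[nH]2)cc1F` is not yet measured. It differs from compound 2 by 3-fluoro-4-methoxyphenyl in place of methyl on a carbonyl carbon, so it restores an aryl group at the same position, now carrying a fluorine and one methoxy rather than two methoxy groups. Within the data shown here, the one measured step that bears on this change is the reverse direction of a 44-fold higher number from compound 1 to compound 2 (1.64 log units; beyond the scatter), which was large. The return of an aryl ketone is therefore expected to bring a large step toward stronger inhibition in this assay, landing compound 3 near compound 1 rather than near compound 2. The estimate for compound 3 in this assay is 700 nM, within 200 nM to 2500 nM, corresponding to an expected step of a 39-fold lower number from compound 2 to compound 3 (1.59 log units; beyond the scatter).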

Compound 3, half-maximal inhibitory concentration: 2700 nM
Compound 3: the middle estimate sits 3.9-fold (0.59 log units) below what was measured, outside the stated range (above it).
By their numbers in this assay, from the lowest: compound 1; then compound 3; then compound 2.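

In this assay, 3-fluoro-4-methoxyphenyl on the carbonyl carbon gives a 10-fold lower number from compound 2 to compound 3 (1.00 log units; beyond the scatter), a modest gain that shows an aryl ketone can recover part of the potency lost with the methyl ketone, though not all of it. The substitution on that aryl group also matters in this series: fluoro in place of methoxy on an aromatic carbon gives a 4.4-fold higher number from compound 1 to compound 3 (0.64 log units; beyond the scatter), a step beyond the scatter, so the aryl ring's presence does not alone set the result. Nothing measured on these compounds accounts for the size of either step.

The three compounds leave open whether the methoxy group that fluoro replaced is specifically favoured, or whether another group on that aromatic carbon, such as hydroxy, chloro or an ethoxy group, would match or exceed it. They also leave open how much of the aryl ketone's advantage over the methyl ketone depends on the aromatic ring itself, a question that a cyclohexyl group or a longer alkyl chain on the carbonyl carbon would address.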